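Aromatic substituent additions in a growth-inhibition series

The compounds below may be only part of what the source reports. "The series", "measured", "known", "first", "only" and "open" are said of these compounds alone.

Measured compounds:
compound 1 `COC(=O)[C@@]1(C)CCC=C2[C@@H]1CC[C@@H](C)[C@]2(C)Cc1c[nH]c2ccccc12` — 5000 nM
compound 2 `COC(=O)[C@@]1(C)CCC=C2[C@@H]1CC[C@@H](C)[C@]2(C)Cc1c[nH]c2c(C)cccc12` — 11000 nM
compound 3 `COC(=O)[C@@]1(C)CCC=C2[C@@H]1CC[C@@H](C)[C@]2(C)Cc1c(C)[nH]c2ccccc12` — 15000 nM

In a functional assay on A549 cells (Homo sapiens) for inhibition, read by sulforhodamine B assay, with a stated time of 48 h (a lower number here means a stronger inhibitor of growth, a higher number a weaker inhibitor of growth), compound 3 gives 15000 nM, the highest of the three numbers. Against compound 1 the step is a 3.0-fold higher number from compound 1 to compound 3 (0.48 log units; beyond the scatter); against compound 2 the two values lie within the scatter of each other.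

Compound 4 `COC(=O)[C@@]1(C)CCC=C2[C@@H]1CC[C@@H](C)[C@]2(C)Cc1c(C)[nH]c2ccc(C(F)(F)F)cc12` differs from compound 3 by trifluoromethyl in place of hydrogen on an aromatic carbon, while the methyl already present in compound 3 stays.

For the measured compounds named here, two measured steps bear on this, both adding a methyl on an aromatic carbon: a 2.2-fold higher number from compound 1 to compound 2 (0.34 log units; beyond the scatter) and a 3.0-fold higher number from compound 1 to compound 3 (0.48 log units; beyond the scatter). Both are modest rises in this assay. Going by the values given here, no measured step covers a trifluoromethyl, nor this place on the ring, so the expectation rests on the pattern that each added aromatic substituent so far has raised the number modestly. A further modest rise, or none beyond the scatter, is therefore expected for compound 4, as a 1.5-fold higher number from compound 3 to compound 4 (0.17 log units; within the scatter).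

The estimate for compound 4 in this assay is 22000 nM, with a range from 8000 nM to 60000 nM.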

Compound 4, concentration for 50% growth inhibition: 17000 nM
Estimate against measurement, compound 4: 1.3-fold (0.11 log units) above; measured number inside the range.
By their numbers in this assay, from the lowest: compound 1; then compounds 2, 3 and 4 (each within the scatter of the next).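

In this assay, trifluoromethyl on the aromatic carbon that is meta to a fused ring and para to a fused ring gives a 1.1-fold higher number from compound 3 to compound 4 (0.05 log units; within the scatter), so this addition, unlike the two methyl additions, a 2.2-fold higher number from compound 1 to compound 2 (0.34 log units; beyond the scatter) and a 3.0-fold higher number from compound 1 to compound 3 (0.48 log units; beyond the scatter), does not move the number beyond the scatter. This position of the six-membered aromatic ring therefore accepts trifluoromethyl with no measurable change in growth inhibition while the methyl of compound 3 stays in place. Nothing among the data shown bears on why this step stays so small.

Still open, as far as these compounds go, is whether an amine, a carboxylic acid or a longer chain at this place would also leave the number unchanged, or would lower it. Also open, from the compounds shown here alone, is whether trifluoromethyl would behave in the same way on the core of compound 1, without the methyl of compound 3.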